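The source may report more compounds than this note shows. Statements on the series, on what has been measured and on what is new or still open speak of the compounds shown alone.

Measured so far in a functional assay on NCI-H460 cells (Homo sapiens) for cytotoxicity, read by MTT assay, with a stated time of 72 h; a lower number here means a stronger inhibitor, a higher number a weaker inhibitor
- Compound 1 `COc1ccc(/C=C2\CNC/C(=C\c3ccc(OC)c(OC)c3)C2=O)cc1OC` gives 6400 nM
- Compound 2 `COc1cc(/C=C2\CNC/C(=C\c3cc(OC)c(OC)c(OC)c3)C2=O)cc(OC)c1OC` gives 1500 nM
- Compound 3 `COc1ccc(/C=C2\CN(C)C/C(=C\c3ccc(OC)c(OC)c3)C2=O)cc1OC` gives 3100 nM

Of these three, compound 2 has the lowest number (1500 nM), so it is the starting point with the strongest cytotoxicity here. Compound 3 comes next (3100 nM) and compound 1 has the highest number (6400 nM).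

Compound 4 `COc1cc(/C=C2\CN(C(=O)C(C)C)C/C(=C\c3cc(OC)c(OC)c(OC)c3)C2=O)cc(OC)c1OC` has not yet been measured. It carries isopropylcarbonyl in place of hydrogen on an amine nitrogen in a ring of compound 2 (isopropylcarbonyl in place of hydrogen on an amine nitrogen in a ring).

Within the data shown here, only one measured step bears on this site, and it is modest but beyond the scatter (a 2.1-fold lower number from compound 1 to compound 3 (0.31 log units; beyond the scatter)). That step puts methyl in place of hydrogen on the same kind of nitrogen. It is a guide with limits, since methyl is a different group and the step was measured on the core of compound 1. Among the measured compounds shown here, no measured step adds isopropylcarbonyl.

A modest move toward a lower number in this assay is therefore expected, though with real uncertainty, and a move the other way cannot be ruled out. The expected change is small (a 1.8-fold lower number from compound 2 to compound 4 (0.25 log units; within the scatter)). For compound 4 the estimated value is 850 nM, with an expected range from 250 nM to 2800 nM.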

Compound 4, half-maximal inhibitory concentration: 2000 nM
Beside the measured number, compound 4's estimate is 2.4-fold (0.37 log units) below it; low and high end bracket the measured number.
By their numbers in this assay, from the lowest: compounds 2, 4 and 3 (each within the scatter of the next, the first and the last beyond it); then compound 1.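

In this assay, putting isopropylcarbonyl in place of hydrogen on the amine nitrogen in the ring gives a 1.3-fold higher number from compound 2 to compound 4 (0.12 log units; within the scatter) and so leaves compound 4 indistinguishable from compound 2. Among these compounds, the only earlier step at this kind of nitrogen (a 2.1-fold lower number from compound 1 to compound 3 (0.31 log units; beyond the scatter)) added just a methyl on the core of compound 1, whereas this one shows that, on the core of compound 2, the nitrogen can lose its hydrogen and carry a group of 5 heavy atoms, including a carbonyl, with the number staying within the scatter. Nothing shown here gives a reason why so large a change at this nitrogen leaves the number within the scatter.

Still open, from the compounds shown here alone, is whether a methyl on the core of compound 2 would give a step like the one seen on the core of compound 1, as the two steps come from different cores and different groups. Also open, going by these compounds, is how far this tolerance extends, for example to a benzoyl group, a longer acyl chain, or a chain ending in an amine or a carboxylic acid on the same nitrogen.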